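A Methoxy Added to the Most Potent Compound

A few compounds are considered here, and "the series" means these few. Any claim that something is new, unique, unknown or untested is made for them only; others in the source may bear on it.

Measured in a functional assay on HeLa cells (Homo sapiens) for antiproliferative activity, read by cell counting, with a stated time of 2 days; a higher number here means a weaker inhibitor, a lower number a stronger inhibitor:
Compound 1 `COc1cccc(Nc2nc(N)c(C(=O)c3ccccc3)s2)c1` gives 3200 nM here
Compound 2 `COc1cc(C(=O)c2sc(Nc3ccccc3)nc2N)cc(OC)c1OC` gives 14 nM here
Compound 3 `COc1ccc(Nc2nc(N)c(C(=O)c3ccccc3)s2)cc1` gives 230 nM here

Compound 2 holds the lowest of the three numbers, and its gaps to compound 3 and to compound 1 both lie beyond the scatter. Compound 4 `COc1ccc(Nc2nc(N)c(C(=O)c3cc(OC)c(OC)c(OC)c3)s2)cc1` has not yet been measured. It differs from compound 2 by one change (methoxy in place of hydrogen on an aromatic carbon), with methoxy in place of hydrogen on an aromatic carbon, turning anilino into (4-methoxyphenyl)amino. Going by the values given here, no measured pair isolates this change, so the evidence is indirect. Compound 3 already carries the 4-methoxyphenyl group and stands at 230 nM on the scale, while compound 1, which lacks that group, stands at 3200 nM on the same scale. Neither number suggests that the group costs much. The expected step of a 1.4-fold lower number from compound 2 to compound 4 (0.15 log units; within the scatter) is therefore small, slightly toward a lower number and not beyond the scatter. The estimate for compound 4 is 10 nM with an expected range of 2 nM to 60 nM overall.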

Compound 4, half-maximal inhibitory concentration: 560 nM
The estimate for compound 4 lay 56-fold (1.75 log units) below the measured number, and the stated range ends below it.
By their numbers in this assay, from the lowest: compound 2; then compound 3; then compound 4; then compound 1.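

Turning anilino into (4-methoxyphenyl)amino gives a 40-fold higher number from compound 2 to compound 4 (1.60 log units; beyond the scatter) in this assay, so this single methoxy, placed para to a large group, carries a large penalty in the setting of compound 2. Going by these compounds alone, no earlier pair isolated this change, and this step is its first direct reading, showing that hydrogen at this place is clearly preferred over methoxy on this compound. The compounds shown offer no measurement that explains the size of this step.

Whether the penalty is specific to methoxy remains open, as a hydroxyl, a fluorine or an amine at the same place is not among the compounds shown. Also open, going by these compounds, is whether the step would be as large with the other parts of compound 2 changed.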